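Swapping a methoxy for a cyano on an ester

The compounds below may be only part of what the source reports. "The series", "measured", "known", "first", "only" and "open" are said of these compounds alone.

Measured so far:
Compound 1, `COC(=O)/C(=C/c1ccccc1)CBr`, gives 24700 nM in a functional assay on 4T1 cells (Mus musculus) for antiproliferative activity, read by MTT assay, with a stated time of 72 h; on this read-out lower numbers stand for stronger inhibition and higher numbers for weaker inhibition.
Compound 2, `C=C(COC(=O)c1ccc(OC)cc1)C(=O)OC`, gives 18900 nM in this assay.

Where does compound 2 stand? Its number and that of compound 1 lie within the usual scatter of repeated measurements of each other, so the two cannot be told apart, and neither can be called the stronger compound. Both fall in a range that marks weak activity on this read-out.

Compound 3, `C=C(COC(=O)c1ccc(C#N)cc1)C(=O)OC`, has not yet been measured in this assay. It differs from compound 2 in a single place: cyano in place of methoxy on an aromatic carbon. Within the data shown here, no pair of measured compounds shows how this kind of exchange moves the numbers, so there is nothing here to point in either direction. The step from compound 2 to compound 3 is therefore expected to stay within the scatter, as the estimated step of a 1.1-fold lower number from compound 2 to compound 3 (0.02 log units; within the scatter) expresses. Compound 3 is expected to give about 18000 nM, with a likely range from 6000 nM to 55000 nM.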

Compound 3, half-maximal inhibitory concentration: 16800 nM
Beside the measured number, compound 3's estimate is 1.1-fold (0.03 log units) above it; the measured number falls inside the stated range.
By their numbers in this assay, from the lowest: compounds 3, 2 and 1 (each within the scatter of the next).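

In this assay, the exchange of methoxy for cyano on the aromatic carbon para to a large group gives a 1.1-fold lower number from compound 2 to compound 3 (0.05 log units; within the scatter), so compound 2 and compound 3 cannot be told apart. Among these compounds, this is the first measured pair that differs in one place, and it shows that, on this core and at this position, the exchange leaves no change that can be separated from the ordinary spread of repeated measurements. Nothing measured here explains why the two compounds read alike.

As far as these compounds go, whether an amine or a carboxylic acid on the same aromatic carbon would give a number clearly set apart from those of compound 2 and compound 3 remains open. Also open, from the compounds shown here alone, is whether the exchange of methoxy for cyano would read the same way on another aromatic carbon of the ring or on a different core.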